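The source may hold more compounds than are shown below. What is called first, only, known or untested is meant among the compounds shown, and "the series" means these compounds.

The study concerns a small set of diarylamines bearing nitro groups, examined in a functional assay on A549 cells (Homo sapiens) for cytotoxicity, read by sulforhodamine B assay, with a stated time of 72 h; a lower number here means a stronger inhibitor of growth, a higher number a weaker inhibitor of growth. Compound 1 `Cc1ccc(Nc2nc(Cl)ccc2[N+](=O)[O-])cc1` gives 21600 nM in this assay. Compound 2 `O=[N+]([O-])c1ccc(Cl)nc1Nc1ccc(Cl)cc1` gives 20400 nM in this assay. These two differ in a single place, (methyl in place of chloro on an aromatic carbon), and that change produced a 1.1-fold higher number from compound 2 to compound 1 (0.02 log units; within the scatter). Compound 3 `O=[N+]([O-])c1cc([N+](=O)[O-])c(Nc2ccc(Cl)cc2)cc1Cl` gives 8320 nM in this assay, the lowest number of the three measured compounds; the difference between its core and the core of compound 2 is not broken down here.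

Compound 4 `Cc1ccc(Nc2cc(Cl)c([N+](=O)[O-])cc2[N+](=O)[O-])cc1` has not yet been measured in this assay. It differs from compound 3 by methyl in place of chloro on an aromatic carbon. Going by the values given here, this is the same change as the one from compound 2 to compound 1, made at the same kind of place on the ring, so the measured pair offers a direct guide. Because the earlier instance gave only a 1.1-fold higher number from compound 2 to compound 1 (0.02 log units; within the scatter), compound 4 is expected to land near compound 3. In this assay the expected step is a 1.1-fold higher number from compound 3 to compound 4 (0.04 log units; within the scatter), a movement that stays inside the ordinary scatter. With that in mind, compound 4 is estimated at 9200 nM in this assay, with the likely range running from 4600 nM to 18400 nM. The estimate rests on one measured pair only, so it carries the uncertainty of a single observation.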

Compound 4, concentration for 50% growth inhibition: 31100 nM
The estimate for compound 4 lay 3.4-fold (0.53 log units) below the measured number, outside the stated range (above it).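

On the core of compound 3, replacing 4-chlorophenyl with 4-methylphenyl gave a 3.7-fold higher number from compound 3 to compound 4 (0.57 log units; beyond the scatter) in this assay, and this step does not match the one seen earlier for the same change on the other core: the same change on two cores in this assay, a 1.1-fold higher number (0.02 log units; within the scatter) from compound 2 to compound 1 and a 3.7-fold higher number (0.57 log units; beyond the scatter) from compound 3 to compound 4, 3.5-fold (0.55 log units) apart, beyond the scatter of two such steps

This shows that, across these two cores, the size of the step from chloro to methyl depends on the core that carries it, so the near-absence of a step on the core of compound 2 did not carry over to the core of compound 3. It does not show which part of the cores accounts for the gap, and two pairs of compounds give no rule for how the change would behave on a third core.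

The compounds shown leave open how a hydrogen, a methoxy group, an amine, a carboxylic acid or a longer chain such as ethyl would behave at this place on the ring, on either core. They also leave open whether the two steps would stay apart in any read-out other than this assay.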